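The source may report more compounds than this note shows. Statements on the series, on what has been measured and on what is new or still open speak of the compounds shown alone.

Measured in a functional assay on HCT-116 cells (Homo sapiens) for inhibition, read by MTT assay, with a stated time of 72 h; a higher number here means a weaker inhibitor of growth, a lower number a stronger inhibitor of growth:
- Compound 1 `O=C(O)/C=C/c1ccncc1-c1ccc2ccccc2c1`: > 30000 nM, a limit of the assay
- Compound 2 `CNC(=O)CCc1ccncc1-c1ccc2ccccc2c1`: 19300 nM
- Compound 3 `NC(=O)/C=C/c1ccncc1-c1ccc2ccccc2c1`: 12100 nM

Compound 3 stands at 12100 nM, and no other number shown is set apart from it. The nearest gap is a 1.6-fold lower number from compound 2 to compound 3 (0.20 log units; within the scatter). Compound 4 `CN(C)C(=O)/C=C/c1ccncc1-c1ccc2ccccc2c1` carries dimethylamino in place of amino on a carbonyl carbon. Within the data shown here, the one measured step at that carbonyl carbon, an at least 2.4-fold lower number from compound 1 to compound 3 (0.39 log units; beyond the scatter), starts from a limit and swaps in amino for hydroxy, so it gives only a loose guide. The gap between the two amides with numbers is the closer guide, and it stays small. The estimated change is a 1.2-fold higher number from compound 3 to compound 4 (0.06 log units; within the scatter), and no shift beyond the scatter is expected. For compound 4 the expected value is 14000 nM, with an estimated range from 6000 nM to 30000 nM.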

Compound 4, concentration for 50% growth inhibition: 4540 nM
Compound 4: the middle estimate sits 3.1-fold (0.49 log units) above what was measured; the measured number lies below the stated range.
By their numbers in this assay, from the lowest: compound 4; then compounds 3 and 2 (each within the scatter of the next). At a limit, above all of these: compound 1.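

In this assay, among these compounds, dimethylamino in place of amino on this carbonyl carbon gives a 2.7-fold lower number from compound 3 to compound 4 (0.43 log units; beyond the scatter), the first step beyond the scatter between two amides with exact numbers. Likewise, 2-(dimethylcarbamoyl)ethenyl in place of 2-(methylcarbamoyl)ethyl gives a 4.3-fold lower number from compound 2 to compound 4 (0.63 log units; beyond the scatter), whereas the earlier pair of amides stayed within the scatter. Dimethylamino in place of hydroxy gives an at least 6.6-fold lower number from compound 1 to compound 4 (0.82 log units; beyond the scatter), only a floor, since the value of compound 1 is a limit: the limit of > 30000 nM in this assay, at which 1 of the 4 values shown sits.

The compounds shown leave open whether methylamino on this carbonyl carbon would fall with amino or with dimethylamino. They also leave open whether diethylamino would lower the number further.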